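The compounds below may be only part of what the source reports. "The series", "measured", "known", "first", "only" and "open" are said of these compounds alone.

Measured in a functional assay on thoracic aorta (Rattus norvegicus, strain Wistar), with a stated time of 15 min; a lower number here means that less compound is needed, a higher number that more compound is needed for the effect:
- compound 1 `COc1ccc(Br)cc1C(C)NC(=O)NS(=O)(=O)c1ccccc1`: > 300000 nM (a limit)
- compound 2 `COc1ccc(F)cc1C(C)NC(=O)NS(=O)(=O)c1ccc(Cl)cc1`: > 300000 nM (a limit)

Within the data shown here, compound 2 has no numeric value in this assay, only a limit, and the one other measured compound offers no number for comparison (the limit of > 300000 nM in this assay, at which 2 of the 2 values shown sit).

The next compound to be measured is compound 3 `COc1ccc(F)cc1C(C)NC(=O)NS(=O)(=O)c1ccccc1`. Relative to compound 2, it has hydrogen in place of chloro on an aromatic carbon, para to a large group, so that 4-chlorophenyl becomes phenyl (hydrogen in place of chloro on an aromatic carbon).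

No measured step sizes this change, so the expectation rests only on the shared limit (the limit of > 300000 nM in this assay, at which 2 of the 2 values shown sit). No change beyond the scatter is expected in this assay, and no direction can be assigned. The estimated step of a number no higher from compound 2 to compound 3 (the limit leaves the size open) is expected to be small. Compound 3 is estimated at 300000 nM, with an expected range from 80000 nM to 500000 nM.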

Compound 3, half-maximal effective concentration: > 300000 nM
Compound 3: a limit, no number; the forecaster's own chance of this, stated with the estimate: 80%; the middle value sits exactly at the limit.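

In this assay compound 3 gives > 300000 nM, a limit. The steps to it from compound 1 and compound 2 therefore cannot be read. The compounds shown leave open how bromo, fluoro, chloro and hydrogen at these places compare, and which change to the shared core would give a numeric value.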